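Cyclopropyl Amide on a Fluoromethyl Core: Solubility Outlook

This account rests on a few compounds, and the source may have more. Where it says the series, first, only, none or still open, it means among the compounds named here.

Three measured compounds frame the question: compound 1 `CNC(=O)c1cc(C(=O)NC2CC2)cc2c1OC[C@H]2c1ccccc1`, compound 2 `CNC(=O)c1cc(C(=O)NC)c2c(c1)[C@H](c1ccccc1)CO2` and compound 3 `CNC(=O)c1cc(C(=O)NC)c2c(c1)[C@H](c1ccccc1)[C@@H](CF)O2`, all examined in a physicochemical assay for solubility; a lower number here means a less soluble compound, a higher number a more soluble compound. In this assay compound 1 gives >= 190 ug/mL, which is a limit of the assay and not a number. Compound 2 gives >= 130 ug/mL, again a limit. Compound 3 gives >= 149 ug/mL, also a limit.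

Two single changes connect them. Compound 1 arises from compound 2 by cyclopropyl in place of methyl on an amide-type nitrogen, and the step that the two limits leave unreadable from compound 2 to compound 1 cannot be read because the limit of >= 130 ug/mL in this assay, at which 1 of the 3 values shown sits, and the limit of >= 190 ug/mL in this assay, at which 1 of the 3 values shown sits, are both limits. Compound 3 arises from compound 2 by fluoromethyl in place of hydrogen on a saturated ring carbon, and the step that the two limits leave unreadable from compound 2 to compound 3 is likewise unreadable because the limit of >= 130 ug/mL in this assay, at which 1 of the 3 values shown sits, and the limit of >= 149 ug/mL in this assay, at which 1 of the 3 values shown sits, are both limits.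

Compound 4 `CNC(=O)c1cc(C(=O)NC2CC2)cc2c1O[C@H](CF)[C@H]2c1ccccc1` has not yet been measured in this assay. It differs from compound 3 by cyclopropyl in place of methyl on an amide-type nitrogen, the same change, at the same kind of place, that turns compound 2 into compound 1; the cores of compound 3 and compound 4 carry the fluoromethyl group that sets compound 3 apart from compound 2. The expected step is a step that the limit leaves unreadable from compound 3 to compound 4, resting on compound 1 at the limit of >= 190 ug/mL in this assay, at which 1 of the 3 values shown sits, and compound 3 at the limit of >= 149 ug/mL in this assay, at which 1 of the 3 values shown sits, both of which sit at limits. Compound 4 is accordingly estimated at 190 ug/mL, between 100 ug/mL and 300 ug/mL, most likely reported once more as a limit.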

Compound 4, solubility: 8 ug/mL
Beside the measured number, compound 4's estimate is 24-fold (1.38 log units) above it; measured number outside the range, below it.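

In this assay, cyclopropyl in place of methyl on an amide-type nitrogen gives an at least 18-fold lower number from compound 3 to compound 4 (1.27 log units; beyond the scatter), while fluoromethyl in place of hydrogen on a saturated ring carbon gives an at least 23-fold lower number from compound 1 to compound 4 (1.37 log units; beyond the scatter). This shows that the cyclopropyl change does not carry over harmlessly onto the core that holds the fluoromethyl group, and that the two changes together end in a far lower number than either single change leaves visible, with compound 4 at 8 ug/mL. It does not show how large the same change is on the core of compound 2, since the steps from compound 2 to compound 1 and to compound 3 both end on limits of the assay and cannot be read, and nothing measured here gives a reason for the fall.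

The compounds shown leave open whether the low number belongs to cyclopropyl itself or only to its pairing with fluoromethyl, and whether ethyl or a longer chain on the amide-type nitrogen would behave in the same way on the core of compound 4. They also leave open whether an amine or a carboxylic acid carried on that core would change the reading in this assay.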